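Indazole substituent swap on a triaryl acrylic acid scaffold

A few compounds are considered here, and "the series" means these few. Any claim that something is new, unique, unknown or untested is made for them only; others in the source may bear on it.

Measured so far:
Compound 1, `CC/C(=C(/c1ccc(/C=C/C(=O)O)cc1)c1cnc2[nH]ncc2c1)c1ccccc1`: 302 nM
Compound 2, `CC/C(=C(/c1ccc(/C=C/C(=O)O)cc1)c1cc(C)c2[nH]ncc2c1)c1ccccc1`: 59 nM

Compound 2 stands lowest of the two numbers in a functional assay on MCF7 cells (Homo sapiens) for cytotoxicity, read by CellTiter-Glo, with a stated time of 5 days; on this read-out lower numbers stand for stronger inhibition and higher numbers for weaker inhibition; its nearest neighbour is compound 1, and the step of a 5.1-fold lower number from compound 1 to compound 2 (0.71 log units; beyond the scatter) lies beyond the scatter. Compound 3, `CC/C(=C(/c1ccc(/C=C/C(=O)O)cc1)c1ccc2[nH]nc(Cl)c2c1)c1ccccc1`, has not yet been measured in this assay. It differs from compound 2 in one place: 3-chloro-1H-indazol-5-yl in place of 7-methyl-1H-indazol-5-yl on a double-bonded chain carbon bound to an aromatic carbon and a double-bonded chain carbon. Going by the values given here, no measured step bears directly on this exchange; the only step known, a 5.1-fold lower number from compound 1 to compound 2 (0.71 log units; beyond the scatter), concerns a different part of the structure and gives no guide to trading the methyl-bearing indazole for the chlorine-bearing one. Both keep the same donor and acceptor count, so compound 3 is expected to give a number close to compound 2, with the step of a 1.2-fold higher number from compound 2 to compound 3 (0.07 log units; within the scatter) estimated as small. The estimate for compound 3 is 70 nM, between 25 nM and 200 nM.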

Compound 3, half-maximal inhibitory concentration: 284 nM
The estimate for compound 3 lay 4.1-fold (0.61 log units) below the measured number; measured number above the stated range.
By their numbers in this assay, from the lowest: compound 2; then compounds 3 and 1 (each within the scatter of the next).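

In this assay, the group on the double-bonded chain carbon moves the number even when the counts of heavy atoms, donors and acceptors stay the same: 3-chloro-1H-indazol-5-yl in place of 7-methyl-1H-indazol-5-yl gives a 4.8-fold higher number from compound 2 to compound 3 (0.68 log units; beyond the scatter) in this exchange. The remaining step, a 1.1-fold lower number from compound 1 to compound 3 (0.03 log units; within the scatter), shows that two different groups at this place can read alike, which leaves compound 2 alone, with a number beyond the scatter of both others. No measurement offered here accounts for the difference between these groups.

From the compounds shown here alone, whether a methoxy group, a fluorine or an amine on the indazole would read like the methyl or like the chlorine stays open. Also open, going by these compounds, is how the methyl and the chlorine would read with their places on the indazole exchanged.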